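This account rests on a few compounds, and the source may have more. Where it says the series, first, only, none or still open, it means among the compounds named here.

Compound 3 `COc1ccc(N/C=C\C(=O)c2nc(-c3ccc(C(F)(F)F)cc3)n3ccccc23)cc1` belongs to a small set of analogs that share one core and differ only in the groups on the two outer benzene rings. In a functional assay on MDA-MB-231 cells (Homo sapiens) for cytotoxicity, read by MTT assay, with a stated time of 48 h (on this read-out higher numbers stand for weaker inhibition and lower numbers for stronger inhibition), compound 3 reaches only the limit of the assay, > 30000 nM. Compound 1 `O=C(/C=C\Nc1ccc(F)cc1)c1nc(-c2ccc(C(F)(F)F)cc2)n2ccccc12` likewise gives only a limit in this assay, > 30000 nM. The step that the two limits leave unreadable from compound 1 to compound 3 therefore cannot be sized, since both values sit at the limit of > 30000 nM in this assay, at which 2 of the 3 values shown sit. Compound 2 `O=C(/C=C\Nc1ccc(Cl)cc1)c1nc(-c2ccc(F)cc2)n2ccccc12`, which carries chloro on one ring and fluoro on the other, gives in this assay 4250 nM. Compound 4 `O=C(/C=C\Nc1ccc(Cl)cc1)c1nc(-c2ccc(C(F)(F)F)cc2)n2ccccc12` differs from compound 3 as follows: chloro in place of methoxy on an aromatic carbon. For the measured compounds named here, no measured step covers this exact change. Compound 2 shows that a chloro-bearing analog can give a number rather than a limit, yet compound 2 also differs from compound 4 in a second place, so its value cannot be carried over directly. Both trifluoromethyl-bearing analogs, compound 1 and compound 3, end at the limit. The step to compound 4 is therefore expected to be an at least 1.5-fold lower number from compound 3 to compound 4 (0.17 log units; that floor lies within the scatter), and whether it can be read at all is uncertain. The estimate for compound 4 in this assay is 20000 nM, between 5000 nM and 60000 nM.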

Compound 4, half-maximal inhibitory concentration: 3840 nM
Beside the measured number, compound 4's estimate is 5.2-fold (0.72 log units) above it; the measured number lies below the stated range.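

On this aromatic carbon, para to a large group, chloro gives a readable number where methoxy and fluoro gave only limits, with an at least 7.8-fold lower number from compound 3 to compound 4 (0.89 log units; beyond the scatter) and an at least 7.8-fold lower number from compound 1 to compound 4 (0.89 log units; beyond the scatter). Trifluoromethyl on the other ring therefore does not by itself hold a compound at the limit, which compound 1 and compound 3 alone could not show. With chloro in place, trifluoromethyl and fluoro on that other ring cannot be told apart in this assay, with a 1.1-fold lower number from compound 2 to compound 4 (0.04 log units; within the scatter).

Methoxy and fluoro on this carbon cannot be ranked against each other, since the step between compound 1 and compound 3 cannot be read: the limit of > 30000 nM in this assay, at which 2 of the 4 values shown sit. On these data alone, whether bromo, methyl or an amine on this carbon would give a number like that of chloro remains open.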